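Cytotoxicity notes on the shared core, compounds 1 to 4

The source may report more compounds than this note shows. Statements on the series, on what has been measured and on what is new or still open speak of the compounds shown alone.

Compound 1 `CCOC(=O)CCCCCOc1cccc(CN(C(=O)c2ccccc2)C(C)C)c1` carries the shared core without an added aryl group. In an ADME assay on BJ cells (Homo sapiens) for cytotoxicity, read by CellTiter-Glo and resazurin assay, with a stated time of 72 h (on this read-out lower numbers stand for an effect already at smaller amounts and higher numbers for an effect only at larger amounts of compound), compound 1 gives only a limit of the assay, > 26000 nM. Compound 2 `CCOC(=O)CCCCCOc1cccc(CN(C(=O)c2ccc(-c3cccnc3)cc2)C(C)C)c1` adds pyridin-3-yl; in this assay compound 2 likewise reaches only a limit, > 26000 nM. Compound 3 `CCOC(=O)CCCCCOc1cccc(CN(C(=O)c2ccc(-c3ccc4cc[nH]c4c3)cc2)C(C)C)c1` adds 1H-indol-6-yl, and in this assay compound 3 also stops at a limit, > 26000 nM. Compound 3 thus stands where the other two stand: the limit of > 26000 nM in this assay, at which 3 of the 3 values shown sit. The steps a step that the two limits leave unreadable from compound 1 to compound 2, a step that the two limits leave unreadable from compound 1 to compound 3 and a step that the two limits leave unreadable from compound 2 to compound 3 are all of unreadable size, as the three limits leave no number to compare.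

Compound 4 `CCOC(=O)CCCCCOc1cccc(CN(C(=O)c2ccc(-c3cccc(OC(F)(F)F)c3)cc2)C(C)C)c1` is not yet measured; it differs from compound 3 in 3-(trifluoromethoxy)phenyl in place of 1H-indol-6-yl on an aromatic carbon. Among the measured compounds shown here, the steps that bear on this change, from compound 1 and compound 2 to compound 3, give no readable size, so no direction can be taken from them. The expected outcome for compound 4 in this assay is a further limit rather than a number, with an estimated step that the limit leaves unreadable from compound 3 to compound 4. Compound 4 is expected to give about 30000 nM, in the range 12000 nM to 80000 nM.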

Compound 4, half-maximal effective concentration: > 26000 nM
Compound 4: no number, only a limit; the forecaster's own chance of this, stated with the estimate: 80%; the middle value does not contradict the limit.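

In this assay, among the compounds shown here, no step from compound 1, compound 2 or compound 3 to compound 4 can be read, since all four compounds stand at one limit: the limit of > 26000 nM in this assay, at which 4 of the 4 values shown sit.
The compounds shown leave open at what concentration, if any, cytotoxicity appears for any of them, and whether the added aryl groups differ.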